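The compounds below may be only part of what the source reports. "The series", "measured", "known", "first", "only" and "open" are said of these compounds alone.

In a functional assay on HCT-116 cells (Homo sapiens) for inhibition, read by MTT assay, with a stated time of 48 h (on this read-out lower numbers stand for stronger inhibition and higher numbers for weaker inhibition), compound 1 `COc1ccc(-n2c(SCc3ccc(C)cc3)nnc2-c2cc(OC)c(OC)c(OC)c2)cc1` gives 33300 nM and compound 3 `COc1cc(-c2nnc(SCc3ccccc3)n2-c2ccc(N(C)C)cc2)cc(OC)c1OC` gives 54000 nM, two numbers within the scatter of each other. Compound 2 `COc1cc(-c2nnc(SC)n2-c2ccc(N(C)C)cc2)cc(OC)c1OC` reads > 60000 nM, which is a limit of the assay and not a number. Compound 4 `COc1cc(-c2nnc(SCc3ccc(C)cc3)n2-c2ccc(N(C)C)cc2)cc(OC)c1OC` differs from compound 3 by methyl in place of hydrogen on an aromatic carbon. Going by the values given here, the one measured step is an at least 1.1-fold lower number from compound 2 to compound 3 (0.04 log units; that floor lies within the scatter), phenyl in place of hydrogen on a saturated chain carbon bound to a sulfur, and its floor lies within the scatter. On that basis, no step beyond the scatter is expected in this assay. The expected change is a 1.2-fold lower number from compound 3 to compound 4 (0.08 log units; within the scatter). Compound 4 is estimated at 45000 nM, with an expected range of 25000 nM to 80000 nM.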

Compound 4, half-maximal inhibitory concentration: > 60000 nM
Compound 4 ended at the assay's limit (the forecaster's own chance of this, stated with the estimate: 25%); middle value at least 1.3-fold (0.12 log units) from the limit.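

Compound 4 reads as a limit of the assay, so methyl on this aromatic carbon can only be given as a floor: an at least 1.1-fold higher number from compound 3 to compound 4 (0.04 log units; that floor lies within the scatter). With the (4-methylbenzyl)sulfanyl group held fixed, the change at the other aromatic ring, dimethylamino in place of methoxy, gives an at least 1.8-fold higher number from compound 1 to compound 4 (0.25 log units; that floor lies within the scatter), which adds a second floor within the scatter. The step between compound 2 and compound 4 cannot be read, since both sit at the limit: the limit of > 60000 nM in this assay, at which 2 of the 4 values shown sit.

Going by these compounds, how far compound 4 lies beyond the limit stays open. So does the effect of an amine or a carboxylic acid in place of this methyl.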